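Long-chain pyrimidinol series: azetidinyl replaced by cyclobutyloxy

The source may hold more compounds than are shown below. What is called first, only, known or untested is meant among the compounds shown, and "the series" means these compounds.

Compound 2 `CCCCCCCCCCCCCCCCc1nc(N2CCC2)nc(OC2CCC2)c1O` gives 103% in a functional assay on cells (Lymphocyte, Homo sapiens), read by a luciferase reporter and ATP content, with a stated time of 48 h, tested at 20 uM (a lower number here means a stronger effect, a higher number a weaker effect of the compound at the concentration tested), the highest of the three numbers, though compound 3 `Cc1nc(OC2CCC2)nc(N2CCC2)c1O` at 96% and compound 1 `CCCCCCCCCCCCCCc1nc(N2CCC2)nc(OC2CCC2)c1O` at 94% both lie within the usual scatter of it. Going by the values given here, the only single-point step, a number 9 percentage points higher from compound 1 to compound 2 (within the scatter), is a chain change and does not bear on the present ring swap. Compound 4 `CCCCCCCCCCCCCCCCc1nc(OC2CCC2)nc(OC2CCC2)c1O` differs from compound 2 by cyclobutyloxy in place of azetidin-1-yl on an aromatic carbon. Among the compounds with values here, no measured step informs this change, so no shift beyond the scatter is expected; the estimated step is a number 3 percentage points lower from compound 2 to compound 4 (within the scatter). Compound 4 is therefore expected to give about 100% in this assay, within a range of 85% to 115%.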

Compound 4, a percentage reported as activity, at one concentration (the size of the read-out at that concentration, not a potency): 96%
Compound 4: middle estimate off by 4 percentage points, on the high side; measured number inside the range.
By their numbers in this assay, from the lowest: compounds 1, 3, 4 and 2 (each within the scatter of the next).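

In this assay the swap to cyclobutyloxy from azetidin-1-yl on the aromatic carbon para to a hydroxy group gives a number 7 percentage points lower from compound 2 to compound 4 (within the scatter) and so leaves the read-out unchanged within the scatter. Going by these compounds alone, the earlier compounds differed in chain length only, so this is the first reading of a change at this position, and here the position tolerates either four-membered ring. No supporting data bear on this result.

Open, from the compounds shown here alone, is whether a dimethylamino, methoxy or carboxylic acid group at this position would move the read-out beyond the scatter. Also open, going by these compounds, is whether the same swap behaves alike on a shorter chain.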